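Microsomal clearance notes: compound 2 to compound 3

The source may hold more compounds than are shown below. What is called first, only, known or untested is meant among the compounds shown, and "the series" means these compounds.

Two compounds of the series have numbers in an ADME assay on microsomes from liver (Homo sapiens) for metabolic stability, read by LC-MS, using NADPH, with stated times of 5 min and 30 min, tested at 1 uM; a lower number here means slower removal, a higher number faster removal of the compound. Compound 1, `CN(C)C(=O)c1cc(-c2cnc(NCc3c(F)ccc4c3CCO4)c3cn[nH]c(=O)c23)n(C)n1`, gives 21 mL.min-1.g-1 in this assay. Compound 2, `O=C(Nc1ccccc1)c1cnc(NCc2c(F)ccc3c2CCO3)n2cnnc12`, gives 14 mL.min-1.g-1 in this assay, the lowest of the two numbers; the gap to compound 1 lies within the scatter, so the two are not separated. Among the measured compounds shown here, no step between measured compounds that differ in one place is available.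

Compound 3, `O=C(Nc1cnc(NCc2c(F)ccc3c2CCO3)n2cnnc12)c1cccnc1`, carries ((pyridin-3-yl)carbonyl)amino in place of phenylcarbamoyl on an aromatic carbon. Nothing in the measured pairs speaks to this change, so no step beyond the scatter in either direction is expected. For compound 3 the expected value in this assay is 13 mL.min-1.g-1, with the range 6 mL.min-1.g-1 to 28 mL.min-1.g-1, because compound 2 sits at 14 mL.min-1.g-1 and no shown step argues for a move. The expected step of a 1.1-fold lower number from compound 2 to compound 3 (0.03 log units; within the scatter) is therefore estimated to stay within the scatter.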

Compound 3, intrinsic clearance in microsomes: < 3 mL.min-1.g-1
Compound 3 gave a limit, no number (the forecaster's own chance of this, stated with the estimate: 10%); at least 4.3-fold (0.63 log units) between middle value and limit.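

The swap of phenylcarbamoyl for ((pyridin-3-yl)carbonyl)amino gives the series its first step between compounds that differ in one place in this assay, an at least 4.6-fold lower number from compound 2 to compound 3 (0.66 log units; beyond the scatter), so the read-out responds to the group at this position. In this assay compound 3 gives < 3 mL.min-1.g-1, which is a limit and not a number, so the true size of the step stays unknown: the limit of < 3 mL.min-1.g-1 in this assay, at which 1 of the 3 values shown sits.

The change is also a double one: the entering group has a hetero atom in its six-membered aromatic ring, and it is attached through its amino nitrogen and not through the carbonyl.

The compounds shown leave open which of these two differences carries the step. A (phenylcarbonyl)amino group or a (pyridin-3-yl)carbamoyl group at this position would separate them.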